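Coumarin-pyrazoline series: fluoro for methoxy on the aryl ring

The source may hold more compounds than are shown below. What is called first, only, known or untested is meant among the compounds shown, and "the series" means these compounds.

Compound 1 is `COc1ccc([C@H]2CC(c3cc4ccccc4oc3=O)=NN2c2ccccc2)cc1`. Within the data shown here, in a functional assay on the whole organism (strain albino) for inhibition, with Rattus norvegicus as the target, read by paw edema, with stated times of 1 h and 4 h, at a dose of 200 mg/kg by the oral route (a lower number here means less inhibition, a higher number more inhibition at the dose given (going by the name of the read-out)), compound 1 gives 36.2%, the second highest of the three numbers so far. Compound 2, `O=c1oc2ccccc2cc1C1=NN(c2ccccc2)[C@@H](c2ccc(Cl)cc2Cl)C1`, gives 67.5% in this assay, and the change was a number 31.3 percentage points higher from compound 1 to compound 2 (beyond the scatter). Compound 3, `O=c1oc2ccccc2cc1C1=NN(c2ccccc2)[C@@H](c2cccc([N+](=O)[O-])c2)C1`, gives 31.2% in this assay, a change of a number 5 percentage points lower from compound 1 to compound 3 (within the scatter), so compound 1 and compound 3 cannot be told apart; the step between the two aryl variants is a number 36.3 percentage points lower from compound 2 to compound 3 (beyond the scatter).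

Compound 4 is `O=c1oc2ccccc2cc1C1=NN(c2ccccc2)[C@@H](c2ccc(F)cc2)C1`. Relative to compound 1 the change is fluoro in place of methoxy on an aromatic carbon. Among the measured compounds shown here, no measured step exchanges a single group on the aryl ring in this way: the step from compound 1 to compound 2 replaces the whole methoxy-bearing ring with a dichloro-bearing one and is large, while the step from compound 1 to compound 3 swaps in a nitro-bearing ring and stays within the scatter. The change to compound 4 is smaller than either, so a step within the scatter is expected, with at most a slight lean upward given that compound 2 carries halogens and gives 67.5%.

For compound 4 in this assay the expected step is a number 5.8 percentage points higher from compound 1 to compound 4 (within the scatter). The estimate for compound 4 is 42%, expected between 25% and 60%.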

Compound 4, a percentage reported as inhibition, in the whole organism at one dose (the size of the read-out at that dose, not a potency): 66.7%
Estimate against measurement, compound 4: 24.7 percentage points below; the whole stated range lies below it.
By their numbers in this assay, from the lowest: compounds 3 and 1 (each within the scatter of the next); then compounds 4 and 2 (each within the scatter of the next).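

In this assay the exchange of methoxy for fluoro, on an aromatic carbon para to a large group, gives a number 30.5 percentage points higher from compound 1 to compound 4 (beyond the scatter) and so shows that this single-group change is enough to move the read-out by a large step, something the earlier whole-ring exchanges could not isolate. The dichloro pattern of compound 2 is not needed for the higher level, since the step of a number 0.8 percentage points lower from compound 2 to compound 4 (within the scatter) leaves the 4-fluorophenyl and 2,4-dichlorophenyl compounds indistinguishable, while a number 35.5 percentage points higher from compound 3 to compound 4 (beyond the scatter) sets compound 4 clearly apart from the 3-nitrophenyl compound as well. Among these four compounds the two halogen-bearing aryl groups therefore stand together above the methoxy and nitro compounds, but no measurement at hand accounts for this grouping.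

On these data alone, whether the gain follows from fluoro itself or from the loss of methoxy stays open, and plain phenyl, 4-chlorophenyl or 4-aminophenyl at this place would help to separate the two. All of these numbers also come from a single oral dose in this assay and describe the size of the read-out at that dose, so they leave relative potency within the series unresolved.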